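Acylating the amine of compound 1

The source may hold more compounds than are shown below. What is called first, only, known or untested is meant among the compounds shown, and "the series" means these compounds.

Measured so far in an ADME assay on L6 cells (Rattus norvegicus) for cytotoxicity, read by resazurin assay, with a stated time of 72 h (a higher number here means a weaker inhibitor, a lower number a stronger inhibitor), with these results
compound 1 `NC1CC2(N3CCCC3)CC(c3ccccc3)C1C(c1ccccc1)C2` gives 38100 nM
compound 2 `CN1CCN(CC(=O)N2CCC3(N4CCCC4)CC(c4ccccc4)C2C(c2ccccc2)C3)CC1` gives 69100 nM
compound 3 `NC1CC2(N3CCCCC3)CC(c3ccccc3)C1C(c1ccccc1)C2` gives 35000 nM

Compound 1 stands within the scatter of both other compounds, so the three numbers form no real order. Compound 4 `CN1CCN(CCC(=O)NC2CC3(N4CCCC4)CC(c4ccccc4)C2C(c2ccccc2)C3)CC1` has not yet been measured. Its change from compound 1 is (2-(4-methylpiperazin-1-yl)ethyl)carbonyl in place of hydrogen on an amine nitrogen and amounts to (2-(4-methylpiperazin-1-yl)ethyl)carbonyl in place of hydrogen on an amine nitrogen. Among the measured compounds shown here, the one measured step is a 1.1-fold lower number from compound 1 to compound 3 (0.04 log units; within the scatter) and it lies within the scatter, but it concerns piperidin-1-yl in place of pyrrolidin-1-yl and not this nitrogen, so it bears only indirectly. For the measured compounds named here, compound 2 also holds a 4-methylpiperazin-1-yl group and gives 69100 nM in this assay while staying within the scatter of compound 1, though no single step links the two. The estimated step is a 1.2-fold higher number from compound 1 to compound 4 (0.07 log units; within the scatter) and no shift beyond the scatter is expected, with a slightly higher number the likelier direction. For compound 4 the estimated value is 45000 nM with an expected range from 18000 nM to 100000 nM as its upper end.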

Compound 4, half-maximal inhibitory concentration: 86700 nM
The estimate for compound 4 lay 1.9-fold (0.28 log units) below the measured number; low and high end bracket the measured number.
By their numbers in this assay, from the lowest: compounds 3, 1, 2 and 4 (each within the scatter of the next, the first and the last beyond it).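

In this assay the amine nitrogen of compound 1 proved to be a place where a change moves the number: (2-(4-methylpiperazin-1-yl)ethyl)carbonyl in place of hydrogen gives a 2.3-fold higher number from compound 1 to compound 4 (0.36 log units; beyond the scatter) and so a modest shift toward weaker inhibition. The only earlier step, on a saturated ring carbon, stayed within the scatter, so this is the first single change shown to go beyond it. No measured evidence accounts for the shift.

This one acyl group leaves open whether the shift belongs to the carbonyl on the amine nitrogen or to the 4-methylpiperazin-1-yl group at the end of the chain. A simple acetyl group on the same nitrogen, or a morpholin-4-yl group in place of the 4-methylpiperazin-1-yl group, would help to separate the two.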